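The source may report more compounds than this note shows. Statements on the series, on what has been measured and on what is new or still open speak of the compounds shown alone.

Measured compounds in the cytotoxicity series:

compound 1 `O=C1O[C@H]([C@@H](O)Cn2cc(-c3cc(C(F)(F)F)cc(C(F)(F)F)c3)nn2)C(OCc2ccccc2)=C1OCc1ccccc1` — 80700 nM
compound 2 `CCCCCc1ccc(-c2cn(C[C@H](O)[C@H]3OC(=O)C(OCc4ccccc4)=C3OCc3ccccc3)nn2)cc1` — > 100000 nM
compound 3 `O=C1O/C(=C\Cn2cc(-c3cc(C(F)(F)F)cc(C(F)(F)F)c3)nn2)C(OCc2ccccc2)=C1OCc1ccccc1` — > 100000 nM

All three were run in an ADME assay on HFF cells (Homo sapiens) for cytotoxicity, read by MTT assay, with a stated time of 72 h; a higher number here means a weaker inhibitor, a lower number a stronger inhibitor. For the measured compounds named here, compound 1 is the only member that returns a number, giving 80700 nM. For compound 2 the result > 100000 nM is a limit of the assay, not a number. For compound 3 the result > 100000 nM is likewise a limit. Compound 2 therefore stands at the limit of > 100000 nM in this assay, at which 2 of the 3 values shown sit, so no ranking of compound 2 against compound 3 is possible, and only compound 1 can be placed on a scale at all.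

The next member, compound 4 `Cc1ccc(-c2cn(C[C@H](O)[C@H]3OC(=O)C(OCc4ccccc4)=C3OCc3ccccc3)nn2)cc1`, differs from compound 2 by hydrogen in place of butyl on a saturated chain carbon bound to an aromatic carbon, so that 4-pentylphenyl becomes 4-methylphenyl. Going by the values given here, no measured pair changes this position, so nothing here tells how much such a change moves this assay. Given that compound 2 reaches only a limit, and that compound 3 with a different core also reaches only a limit, the expected step of a number no higher from compound 2 to compound 4 (the limit leaves the size open) is none beyond the scatter. Compound 4 is expected at 100000 nM, with a range from 40000 nM to 300000 nM, and most probably again reported only as a limit.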

Compound 4, half-maximal inhibitory concentration: > 100000 nM
Compound 4: a limit, no number; the forecaster's own chance of this, stated with the estimate: 70%; the middle value lies on the limit itself.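

In this assay compound 4 gives > 100000 nM, which is a limit and not a number. Compound 2 gives > 100000 nM, also a limit. For the compounds shown here, no step can therefore be read between compound 2 and compound 4. The compounds shown leave open whether replacing 4-pentylphenyl with 4-methylphenyl moves this assay's read-out at all.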